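Trimming an Octyl Chain Down to Isopropyl

The source may hold more compounds than are shown below. What is called first, only, known or untested is meant among the compounds shown, and "the series" means these compounds.

Compound 1 `CCCCCCCC/C(=C\C=C\C(=O)N[C@H](C)CCCc1cccnc1)c1ccc(OC)cc1` was tested in a functional assay on the whole organism for inhibition, with Cavia porcellus as the target, with a stated time of 2 h (on this read-out lower numbers stand for an effect already at smaller amounts and higher numbers for an effect only at larger amounts of compound), and gives 13 mg/kg. Compound 2 `COc1ccc(C(=C/C=C/C(=O)NCCCCc2cccnc2)c2ccc(OC)cc2)cc1` gives 12 mg/kg in this assay, and the two numbers lie within the usual scatter of each other, so they cannot be told apart. Compound 3 `COc1ccc(/C(=C/C=C/C(=O)N[C@H](C)CCCc2cccnc2)C(C)C)cc1` has not been measured. It differs from compound 1 in one place: isopropyl in place of octyl on a double-bonded chain carbon bound to an aromatic carbon and a double-bonded chain carbon. Among the compounds with values here, no measured pair shows this change, so the expectation rests on compound 1 alone. The step of a 1.2-fold higher number from compound 1 to compound 3 (0.06 log units; within the scatter) is expected to stay within the scatter, with no clear direction. Compound 3 is estimated at 15 mg/kg, with a range from 6 mg/kg to 40 mg/kg.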

Compound 3, dose for 50% inhibition: 30 mg/kg
Estimate against measurement, compound 3: 2.0-fold (0.30 log units) below, and the stated range covers the measured number.
By their numbers in this assay, from the lowest: compounds 2 and 1 (each within the scatter of the next); then compound 3.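

At this position, on a double-bonded chain carbon bound to an aromatic carbon and a double-bonded chain carbon, the group can be seen to matter: in this assay isopropyl in place of octyl gives a 2.3-fold higher number from compound 1 to compound 3 (0.36 log units; beyond the scatter) and so needs a larger dose for the same effect. Within the data shown here, the step is modest, but it is the first single change here that lies beyond the scatter. No measurement shown gives a reason for this shift.

Two chain lengths cannot show a trend. A butyl group or a longer decyl chain here would test whether the dose keeps changing with length.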